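Compound 4 Expected to Sit Close to Compound 1

A few compounds are considered here, and "the series" means these few. Any claim that something is new, unique, unknown or untested is made for them only; others in the source may bear on it.

Among the compounds with values here, compound 1 `Cc1ccc2c(=O)c(CSC(=S)N(C(C)C)C(C)C)coc2c1` gives 700 nM in a functional assay on HEp-2 cells (Homo sapiens) for antiproliferative activity, read by MTT assay, with a stated time of 72 h (a higher number here means a weaker inhibitor, a lower number a stronger inhibitor), the lowest of the three numbers measured so far. Compound 2 `CC(C)N(C(=S)SCc1coc2cc(Cl)ccc2c1=O)C(C)C`, with chloro in place of methyl on an aromatic carbon, gives 4200 nM, and compound 3 `CC(C)N(C(=S)SCc1coc2ccccc2c1=O)C(C)C`, with hydrogen in place of methyl on an aromatic carbon, gives 3000 nM. The steps of a 6.0-fold higher number from compound 1 to compound 2 (0.78 log units; beyond the scatter) and a 4.3-fold higher number from compound 1 to compound 3 (0.63 log units; beyond the scatter) are modest, while a 1.4-fold lower number from compound 2 to compound 3 (0.15 log units; within the scatter) lies within the scatter. Compound 4 `Cc1ccc2c(=O)c(CSC(=S)N3CCCCC3)coc2c1` differs from compound 1 at a different place: piperidin-1-yl in place of diisopropylamino on a thiocarbonyl carbon. Within the data shown here, none of the measured steps concerns that place, so the data offer no direct guide. The expectation is therefore a step of a 1.4-fold higher number from compound 1 to compound 4 (0.15 log units; within the scatter), none beyond the scatter, with wide uncertainty. Compound 4 is estimated at 1000 nM, within a range from 300 nM to 3500 nM.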

Compound 4, half-maximal inhibitory concentration: 900 nM
The estimate for compound 4 lay 1.1-fold (0.05 log units) above the measured number; low and high end bracket the measured number.
By their numbers in this assay, from the lowest: compounds 1 and 4 (each within the scatter of the next); then compounds 3 and 2 (each within the scatter of the next).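

Where the earlier steps all changed a group on an aromatic carbon, this one changes the group on the thiocarbonyl carbon, and in this assay piperidin-1-yl in place of diisopropylamino gives a 1.3-fold higher number from compound 1 to compound 4 (0.11 log units; within the scatter). For this one pair, then, an open-chain amino group and a six-membered ring with one heavy atom fewer read alike at this place. No measurement shown here offers an explanation for this. Open, on these data alone, is whether morpholin-4-yl or dimethylamino would read alike at the same place. Also open, as far as these compounds go, is whether methyl, chloro and hydrogen on the aromatic carbon would differ as they do when piperidin-1-yl is present.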